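The compounds below may be only part of what the source reports. "The series", "measured", "known", "first", "only" and "open" are said of these compounds alone.

Compound 2 `COc1ccc2c(=O)c(/C=C/C(=O)Nc3ccccc3C)coc2c1` is the stronger of the two measured compounds in a functional assay on HeLa cells (Homo sapiens) for inhibition, read by MTT assay, with a stated time of 48 h; on this read-out lower numbers stand for stronger inhibition and higher numbers for weaker inhibition: compound 2 gives 7270 nM, whereas compound 1 `COc1ccc2c(=O)c(/C=C/C(=O)NCc3cccc(F)c3)coc2c1` gives 17600 nM. Going by the values given here, the only measured step, a 2.4-fold lower number from compound 1 to compound 2 (0.38 log units; beyond the scatter), swaps a 3-fluorobenzyl for a 2-methylphenyl on the amide-type nitrogen, so it changes both the spacing and the ring substituent at once. Compound 3 `COc1ccc2c(=O)c(/C=C/C(=O)Nc3ccc(F)cc3)coc2c1` differs from compound 2 in one place: 4-fluorophenyl in place of 2-methylphenyl on an amide-type nitrogen. Among the compounds with values here, neither measured compound carries a 4-fluorophenyl, and no measured step isolates the substituent on a directly attached phenyl ring, so the one measured step bears on this change only loosely; it shows that the amide-type nitrogen tolerates an aryl group directly, and the two compounds together suggest the aryl amides of this core sit in a narrow band. The step to compound 3 is therefore expected to be small, likely within the scatter in either direction, an estimated 1.1-fold higher number from compound 2 to compound 3 (0.04 log units; within the scatter). Compound 3 is expected to give about 8000 nM in this assay, with a plausible range from 3000 nM to 22000 nM.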

Compound 3, half-maximal inhibitory concentration: 9680 nM
For compound 3 the middle estimate is 1.2-fold (0.08 log units) below the measured one, and the stated range covers the measured number.
By their numbers in this assay, from the lowest: compounds 2, 3 and 1 (each within the scatter of the next, the first and the last beyond it).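

In this assay the exchange of 2-methylphenyl for 4-fluorophenyl on the amide-type nitrogen gives a 1.3-fold higher number from compound 2 to compound 3 (0.12 log units; within the scatter) so these two directly attached aryl groups cannot be told apart on this read-out. At the same nitrogen, 4-fluorophenyl in place of 3-fluorobenzyl gives a 1.8-fold lower number from compound 1 to compound 3 (0.26 log units; within the scatter) and so does not clear the scatter, whereas 2-methylphenyl in place of the same group gave a 2.4-fold lower number from compound 1 to compound 2 (0.38 log units; beyond the scatter) and did, which means that a clear gain on going from this benzyl group to a directly attached aryl group holds for compound 2 but not for compound 3. Nothing measured here accounts for either result.

The compounds shown leave open how a 4-methylphenyl or a 2-fluorophenyl would read, and these two groups would separate the identity of the ring substituent from its place on the ring. Also open, as far as these compounds go, is whether a group of another kind on this nitrogen, such as a pyridyl ring, a phenyl ring carrying a carboxylic acid or a longer chain, would move the number beyond the scatter of these three.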